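Shortening the butyl chain: working notes on compound 3

The source may report more compounds than this note shows. Statements on the series, on what has been measured and on what is new or still open speak of the compounds shown alone.

compound 1 `CCCCc1ccc(C(=O)N/N=C/c2ccc([N+](=O)[O-])o2)cc1` gives > 200000 nM as a limit
compound 2 `O=C(N/N=C/c1ccc([N+](=O)[O-])o1)c1ccccc1Oc1ccccc1` gives > 200000 nM as a limit

In an ADME assay on LL24 cells (Homo sapiens) for inhibition, read by MTT assay, with a stated time of 24 h (a lower number here means a stronger inhibitor, a higher number a weaker inhibitor), compound 1 gives > 200000 nM as a limit of the assay and not a number. Among the compounds with values here, the series stands at the limit of > 200000 nM in this assay, at which 2 of the 2 values shown sit, and offers no number to compare, so no measured step is available.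

Within the data shown here, compound 3 `CCCc1ccc(C(=O)N/N=C/c2ccc([N+](=O)[O-])o2)cc1` carries hydrogen in place of methyl on a saturated chain carbon, three bonds along the chain from an aromatic carbon as its one difference from compound 1, a change that also reads butyl to propyl.

The expectation rests only on compound 1 giving > 200000 nM as a limit. The expected a number no higher from compound 1 to compound 3 (the limit leaves the size open) in this assay lies within the scatter, in no particular direction, and another limit is the likeliest report. For compound 3 the estimate is 200000 nM with an expected range from 80000 nM to 400000 nM in these notes.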

Compound 3, half-maximal inhibitory concentration: 89000 nM
Compound 3: the middle estimate sits 2.2-fold (0.35 log units) above what was measured; measured number inside the range.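

In this assay, the change from butyl to propyl on the saturated chain gives an at least 2.2-fold lower number from compound 1 to compound 3 (0.35 log units; beyond the scatter), which makes this chain position the first place in the series where a single change yields a readable number. The value of compound 1 is a limit and not a number, so the step has a least size but no upper bound. Compound 3 therefore stands as the only compound shown with a true number, and the remainder of the series gives no value to set beside it: the limit of > 200000 nM in this assay, at which 2 of the 3 values shown sit.

As far as these compounds go, whether the lower number continues with a still shorter chain, such as ethyl or methyl, remains open. Also open, from the compounds shown here alone, is how an amine or a carboxylic acid at the end of the propyl chain would read in this assay.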